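The source may hold more compounds than are shown below. What is called first, only, known or untested is meant among the compounds shown, and "the series" means these compounds.

Compound 1 `CC1=C(C(=O)OC2CCCC2)C(c2ccco2)NC(=O)N1` is an ester built on a six-membered ring core with a cyclopentyl on the ester oxygen and a furan-2-yl on a saturated ring carbon. In an assay on membranes from HeLa cells for displacement of a labelled ligand from adenosine receptor A3 (Homo sapiens), read by scintillation counting, with a stated time of 180 min, tested at 1 uM (on this read-out lower numbers stand for less inhibition and higher numbers for more inhibition at the one concentration tested (going by the name of the read-out)), compound 1 gives 14%. Compound 2 `CC1=C(C(=O)OC2CCCCC2)C(c2ccco2)NC(=O)N1` differs from compound 1 in one place, (cyclohexyl in place of cyclopentyl on an oxygen next to a carbonyl group). In this assay compound 2 gives 4%, which is a number 10 percentage points lower from compound 1 to compound 2 (within the scatter). Compound 3 `CC1=C(C(=O)OC2CCCC2)C(c2cccs2)NC(=O)N1` keeps the cyclopentyl of compound 1 but differs from it in another place, (thiophen-2-yl in place of furan-2-yl on a saturated ring carbon). In this assay compound 3 gives 1%, which is a number 13 percentage points lower from compound 1 to compound 3 (beyond the scatter). The values of compound 2 and compound 3 lie within the usual scatter of each other, so nothing is said here about which of the two sits higher.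

Compound 4 `CC1=C(C(=O)OC2CCCCC2)C(c2cccs2)NC(=O)N1` has not yet been measured. It differs from compound 3 by cyclohexyl in place of cyclopentyl on an oxygen next to a carbonyl group, the same change that separates compound 1 from compound 2, now carried out on the core of compound 3 instead of the core of compound 1; the two cores differ in the way just described for compound 3. The expectation for compound 4 rests on two things: the change from compound 1 to compound 2 produced only a number 10 percentage points lower from compound 1 to compound 2 (within the scatter), a step that stays within the scatter, and compound 3 already starts from 1%. Compound 4 is therefore expected to show a step of a number 1 percentage points lower from compound 3 to compound 4 (within the scatter) in this assay, so that its estimated value is 0%, with a likely range from -7% to 8%.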

Compound 4, a percentage reported as inhibition, at one concentration (the size of the read-out at that concentration, not a potency): 1%
The estimate for compound 4 lay 1 percentage points below the measured number; low and high end bracket the measured number.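

In this assay, putting cyclohexyl in place of cyclopentyl on the oxygen next to a carbonyl group gives no change at the digits printed from compound 3 to compound 4 (within the scatter), and the step carries over from one core to the other without a difference that can be told apart: the same change on two cores in this assay, a number 10 percentage points lower (within the scatter) from compound 1 to compound 2 and no change at the digits printed (within the scatter) from compound 3 to compound 4, 10 percentage points apart, within the scatter of two such steps. The other change, thiophen-2-yl in place of furan-2-yl on the saturated ring carbon, gives a number 3 percentage points lower from compound 2 to compound 4 (within the scatter), and it too reads alike on both cores: the same change on two cores in this assay, a number 13 percentage points lower (beyond the scatter) from compound 1 to compound 3 and a number 3 percentage points lower (within the scatter) from compound 2 to compound 4, 10 percentage points apart, within the scatter of two such steps. Among the compounds shown here, this shows only that the four compounds fit the idea of a change that carries over, and it does not prove that the change acts the same way on every core, since compound 3 gives 1% and leaves almost no room for a lower number, and a reading at one concentration is not a potency.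

The compounds shown carry only two ring groups on the ester oxygen and only two five-membered aromatic rings on the saturated ring carbon. Open, therefore, is how a longer chain on that oxygen, or a phenyl ring or an amine-bearing group on that ring carbon, would read, and whether any such compound would lift the numbers high enough for a step to be seen clearly.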